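Pyrazole change from compound 3 to compound 4

The source may report more compounds than this note shows. Statements on the series, on what has been measured and on what is new or still open speak of the compounds shown alone.

Compound 1 `Clc1ccc2c(c1-c1ccn[nH]1)CCC2c1ncc[nH]1` carries a 1H-pyrazol-5-yl group on the shared core. In a functional assay on CHO cells for agonist activity at Alpha-1B adrenergic receptor (Homo sapiens), read by FLIPR and calcium flux (on this read-out higher numbers stand for an effect only at larger amounts of compound and lower numbers for an effect already at smaller amounts), compound 1 gives > 10000 nM, which is a limit of the assay and not a number. Compound 2 `Cn1cc(-c2cccc3c2CCC3c2ncc[nH]2)cn1` gives > 10000 nM in this assay, again a limit. Compound 3 `Cn1ccc(-c2cccc3c2CCC3c2ncc[nH]2)n1` gives > 10000 nM in this assay, also a limit, so compound 3 stands at the same limit as the other two and not at a measured number. Within the data shown here, the single step with a changed group, a step that the two limits leave unreadable from compound 2 to compound 3, is therefore not readable in size. All that the series shows is the limit of > 10000 nM in this assay, at which 3 of the 3 values shown sit.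

Compound 4 `c1cc(-c2ccn[nH]2)c2c(c1)C(c1ncc[nH]1)CC2` differs from compound 3 by 1H-pyrazol-5-yl in place of 1-methyl-1H-pyrazol-3-yl on an aromatic carbon. Among the measured compounds shown here, no measured step is available to set the direction or size of this change, since every value so far sits at the limit. Compound 4 is therefore expected at or beyond that limit, with an estimated step that the limit leaves unreadable from compound 3 to compound 4. The estimate for compound 4 in this assay is 15000 nM, within the range 4000 nM to 60000 nM.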

Compound 4, half-maximal effective concentration: 600 nM
Estimate against measurement, compound 4: 25-fold (1.40 log units) above, and the stated range ends above it.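

In this assay, 1H-pyrazol-5-yl in place of 1-methyl-1H-pyrazol-3-yl gives an at least 16-fold lower number from compound 3 to compound 4 (1.22 log units; beyond the scatter), and in place of 1-methyl-1H-pyrazol-4-yl it gives an at least 16-fold lower number from compound 2 to compound 4 (1.22 log units; beyond the scatter), so the pyrazole on this aromatic carbon now shows a readable effect on the number. Compound 1 carries the same 1H-pyrazol-5-yl and goes against any pattern resting on the pyrazole alone, with hydrogen in place of chloro on an aromatic carbon giving an at least 16-fold lower number from compound 1 to compound 4 (1.22 log units; beyond the scatter). Each of these steps starts from a limit, so its true size stays open: the limit of > 10000 nM in this assay, at which 3 of the 4 values shown sit.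

The step between compound 2 and compound 3 cannot be read. The compounds shown leave open whether a fluoro or methyl group in place of chloro, or a 1,2,3-triazole in place of the pyrazole, would keep the value of compound 4.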